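This account rests on a few compounds, and the source may have more. Where it says the series, first, only, none or still open, it means among the compounds named here.

For the measured compounds named here, in a functional assay on OVCAR-3 cells (Homo sapiens) for cytotoxicity, read by MTT assay, with a stated time of 6 days (a lower number here means a stronger inhibitor, a higher number a weaker inhibitor), only two compounds have been tested so far. Compound 1 `COc1ccc(NC(=O)SC[C@H](NC(C)=O)C(=O)O)cc1` gives > 200000 nM, which is a limit of the assay and not a number. Going by the values given here, compound 2 `CC(=O)N[C@@H](CSC(=O)Nc1ccccc1)C(=O)O` gives 153000 nM, the only true number available, so its standing rests on a single comparison. Compound 3 `CC(=O)N[C@@H](CSC(=O)Nc1ccc(I)cc1)C(=O)O` follows from compound 2 through iodo in place of hydrogen on an aromatic carbon. Among the compounds with values here, the one measured step that bears on this change is an at least 1.3-fold lower number from compound 1 to compound 2 (0.11 log units; that floor lies within the scatter). As far as these compounds go, the true size of that step stays open because of the limit of > 200000 nM in this assay, at which 1 of the 2 values shown sits. It also involves methoxy, not iodo, so it is weak guidance. No step beyond the scatter is therefore expected in this assay, and no firm direction. The estimated change is a 1.3-fold lower number from compound 2 to compound 3 (0.11 log units; within the scatter). Compound 3 is expected at 120000 nM, with an estimated range of 45000 nM to 260000 nM.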

Compound 3, half-maximal inhibitory concentration: > 200000 nM
Compound 3: only a limit was reported; the forecaster's own chance of this, stated with the estimate: 15%; at least 1.6-fold (0.22 log units) between middle value and limit.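

In this assay, iodo in place of hydrogen on an aromatic carbon, para to a large group, gives an at least 1.3-fold higher number from compound 2 to compound 3 (0.11 log units; that floor lies within the scatter). Compound 3 gives > 200000 nM, which is a limit of the assay and not a number. Both replacements of hydrogen at this position, methoxy and iodo, now end at a limit, leaving compound 2 as the only compound with a true number, and the step between the two limits cannot be read: the limit of > 200000 nM in this assay, at which 2 of the 3 values shown sit.

As far as these compounds go, how far compound 1 and compound 3 really lie from compound 2 stays open, as does whether any group at this position can give a lower number than hydrogen does. From the compounds shown here alone, what an amine or a chloro group in this place would do to the number also remains open.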